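Swapping the Amine Group on a Three-Carbon Ether Chain

The source may hold more compounds than are shown below. What is called first, only, known or untested is meant among the compounds shown, and "the series" means these compounds.

Compound 1 `COc1cc2c(Nc3ccc(C#N)cc3)ncnc2cc1OCCCN1CCCC1`: 8080 nM
Compound 2 `COc1cc2c(Nc3ccc(C#N)cc3)ncnc2cc1OCCCN1CCC(O)CC1`: > 100000 nM

Both results come from a functional assay on SH-SY5Y cells (Homo sapiens) for antiproliferative activity, read by MTT assay, with a stated time of 72 h; on this read-out higher numbers stand for weaker inhibition and lower numbers for stronger inhibition. Compound 2 stands at the limit of > 100000 nM in this assay, at which 1 of the 2 values shown sits, so it has only a limit and no exact number. Going by the values given here, only one measured step bears on what follows: an at least 12-fold higher number from compound 1 to compound 2 (1.09 log units; beyond the scatter), with 4-hydroxypiperidin-1-yl in place of pyrrolidin-1-yl.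

Compound 3 `COc1cc2c(Nc3ccc(C#N)cc3)ncnc2cc1OCCCN1CCCCC1CCO` changes the same place. It has 2-(2-hydroxyethyl)piperidin-1-yl in place of 4-hydroxypiperidin-1-yl (2-(2-hydroxyethyl)piperidin-1-yl in place of 4-hydroxypiperidin-1-yl on a saturated chain carbon, three bonds along the chain from an oxygen on an aromatic ring). Exchanging the group at this place moved the number strongly in the one case measured, so a sizeable change is possible here too. A move towards lower numbers is expected, though its size is uncertain and compound 3 could also reach the limit. The expected step is an at least 4.0-fold lower number from compound 2 to compound 3 (0.60 log units; beyond the scatter). For compound 3 the estimated value is 25000 nM, with an expected range from 6000 nM to 100000 nM.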

Compound 3, half-maximal inhibitory concentration: > 100000 nM
Compound 3: only a limit was reported (the forecaster's own chance of this, stated with the estimate: 25%); middle value at least 4.0-fold (0.60 log units) from the limit.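

Compound 3 gives > 100000 nM, which is a limit and not a number. The loss seen with 4-hydroxypiperidin-1-yl is therefore not confined to that one group: 2-(2-hydroxyethyl)piperidin-1-yl in place of pyrrolidin-1-yl gives an at least 12-fold higher number from compound 1 to compound 3 (1.09 log units; beyond the scatter), which leaves compound 1 as the only one of the three with an exact number. The step between compound 2 and compound 3 cannot be read, because both stop at the same limit: the limit of > 100000 nM in this assay, at which 2 of the 3 values shown sit.

As far as these compounds go, it remains open whether the loss goes with the six-membered ring or with the hydroxyl group, which a plain piperidin-1-yl or a 3-hydroxypyrrolidin-1-yl on the same chain could help to separate. From the compounds shown here alone, it is also open how morpholin-4-yl or dimethylamino would behave at this place.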